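The source may report more compounds than this note shows. Statements on the series, on what has been measured and on what is new or still open speak of the compounds shown alone.

Compound 1 `COc1cccc(CN2C(=O)CN(C(=O)c3cc4cc(OC)ccc4o3)C[C@@H]2CCc2ccccc2)c1` gives 0.128 h in an ADME assay on microsomes from liver (Homo sapiens) for metabolic stability, with a stated time of 30 min, tested at 1 uM; a higher number here means that the compound lasts longer, a lower number that the compound disappears faster.
Compound 2 `COc1ccc2[nH]c(C(=O)N3CC(=O)N(Cc4ccccc4)[C@@H](CCc4ccccc4)C3)cc2c1` gives 0.167 h in this assay.
Compound 3 `COc1ccc2[nH]c(C(=O)N3CC(=O)N(Cc4ccccc4)[C@@H](CN4CCCCC4)C3)cc2c1` gives 0.283 h in this assay.

Compound 3 has the highest number of the three, although its gap to compound 2 is within the scatter; only its gap to compound 1 is beyond it. Compound 4 `COc1ccc2[nH]c(C(=O)N3CC(=O)N(Cc4ccccc4)[C@@H](CN4CCc5ccccc5C4)C3)cc2c1` differs from compound 3 in one place: 1,2,3,4-tetrahydroisoquinolin-2-yl in place of piperidin-1-yl on a saturated chain carbon bound to a saturated ring carbon. Within the data shown here, the only measured step at that same place is a 1.7-fold higher number from compound 2 to compound 3 (0.23 log units; within the scatter), and it stayed within the scatter. Among the measured compounds shown here, no measured pair shows a change of this kind, so no step beyond the scatter is expected in this assay. Compound 4 is therefore estimated to give about 0.25 h, with a range from 0.12 h to 0.5 h. That estimate means a 1.1-fold lower number from compound 3 to compound 4 (0.05 log units; within the scatter), expected to lie within the scatter.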

Compound 4, half-life: 0.617 h
Compound 4: middle estimate off by 2.5-fold (0.39 log units), on the low side; measured number outside the range, above it.
By their numbers in this assay, from the lowest: compounds 1, 2 and 3 (each within the scatter of the next, the first and the last beyond it); then compound 4.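

Among these compounds, at the place on a saturated chain carbon bound to a saturated ring carbon, this change gives the first steps beyond the scatter in this assay: a 2.2-fold higher number from compound 3 to compound 4 (0.34 log units; beyond the scatter) and a 3.7-fold higher number from compound 2 to compound 4 (0.57 log units; beyond the scatter). The entering 1,2,3,4-tetrahydroisoquinolin-2-yl keeps a six-membered non-aromatic ring and adds an aromatic ring of carbon only, so the half-life does respond to the group at this place. Nothing available here gives a cause for the rise.

On these data alone, whether a morpholin-4-yl or dimethylamino group at this place would give a similar half-life remains open. So does the effect of a fluoro group on the new aromatic ring.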